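Replacing the Dioxolane with an Ethyl Ester

The compounds below may be only part of what the source reports. "The series", "measured", "known", "first", "only" and "open" are said of these compounds alone.

Measured compounds in a functional assay on B16 cells (Mus musculus) for cytotoxicity, read by MTT assay, with a stated time of 48 h; a higher number here means a weaker inhibitor, a lower number a stronger inhibitor:
compound 1 `CC1(C)OC[C@H](Cn2cc(-c3ccc([N+](=O)[O-])cc3)nn2)O1`: > 100000 nM (a limit of the assay, not a number)
compound 2 `O=[N+]([O-])c1ccc(-c2cn(Cc3ccccc3)nn2)cc1`: 5120 nM
compound 3 `CC1(C)OCC(Cn2cc(-c3ccc([N+](=O)[O-])cc3)nn2)O1`: > 100000 nM (a limit of the assay, not a number)

Compound 3 therefore stands at the limit of this assay, where compound 1 also sits, and only compound 2 carries a number. The pair of compound 1 and compound 3 cannot be ranked against each other because of the limit of > 100000 nM in this assay, at which 2 of the 3 values shown sit; they differ only in that (the fact that one of compounds 1 and 3 is drawn with a defined configuration and the other without, at the place where they differ). For the measured compounds named here, the one readable change on the saturated chain carbon bound to the aromatic nitrogen is an at least 19-fold higher number from compound 2 to compound 3 (1.29 log units; beyond the scatter), with its mirror an at least 19-fold lower number from compound 1 to compound 2 (1.29 log units; beyond the scatter).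

Compound 4 `CCOC(=O)Cn1cc(-c2ccc([N+](=O)[O-])cc2)nn1` is the next member. Its difference from compound 3 is ethoxycarbonyl in place of 2,2-dimethyl-1,3-dioxolan-4-yl on a saturated chain carbon bound to an aromatic nitrogen. Neither measured step covers an ethoxycarbonyl: the two steps only show that the 2,2-dimethyl-1,3-dioxolan-4-yl sits at the limit and the phenyl gives a number. With the dioxolane gone, compound 4 is expected to move to a lower number by a large amount, an at least 2.5-fold lower number from compound 3 to compound 4 (0.39 log units; beyond the scatter), but not to reach compound 2, whose 5120 nM rests on a phenyl. Compound 4 is thus estimated at 40000 nM, within 10000 nM to 150000 nM, with a real chance that only a limit is reported.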

Compound 4, half-maximal inhibitory concentration: > 100000 nM
Compound 4: no number, only a limit (the forecaster's own chance of this, stated with the estimate: 45%); middle value at least 2.5-fold (0.39 log units) away from the limit.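

In this assay, the ethoxycarbonyl shows that a group without a ring at this position, on a saturated chain carbon bound to an aromatic nitrogen, can also stay at the limit of the assay, so losing the ring of the 2,2-dimethyl-1,3-dioxolan-4-yl does not by itself yield a number. Among the groups shown at this place, phenyl remains the only one with a measured number, and the change to ethoxycarbonyl gives an at least 19-fold higher number from compound 2 to compound 4 (1.29 log units; beyond the scatter). The steps to compound 4 from compound 1 and from compound 3 cannot be read, and the ethoxycarbonyl and the 2,2-dimethyl-1,3-dioxolan-4-yl cannot be ranked against each other, because of this: the limit of > 100000 nM in this assay, at which 3 of the 4 values shown sit.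

On these data alone, how far apart these compounds lie beyond the limit remains open, as does whether the ring of the phenyl, its aromatic character or some other feature accounts for the number of compound 2. Also open, as far as these compounds go, is how a carboxylic acid, a primary amide or a longer chain ending in phenyl would behave at this position on the same core.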